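The compounds below may be only part of what the source reports. "The series", "measured", "known", "first", "only" and "open" are said of these compounds alone.

Measured compounds in an assay for inhibition of Dihydrofolate reductase (Homo sapiens); on this read-out lower numbers stand for lower potency and higher numbers for higher potency (the scale is a negative logarithm):
- compound 1, `Cc1cccc2nc(N)nc(N)c12`: 6.09
- compound 2, `Nc1nc(N)c2c(Cl)c(Br)ccc2n1`: 7
- compound 3, `Nc1nc(N)c2c(Cl)c(N)ccc2n1`: 6.18

Compound 3 holds the second highest of the three numbers in this assay. Its value and that of compound 1 lie within the scatter of each other, so no order between them can be read. Among the measured compounds shown here, compound 2 stands clearly higher: the step of a number 0.82 log units lower from compound 2 to compound 3 (beyond the scatter) is the one change beyond the scatter in this small set.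

The next compound, compound 4, `Nc1nc(N)c2c(Cl)cccc2n1`, differs from compound 3 in one place: hydrogen in place of amino on an aromatic carbon. For the measured compounds named here, no measured pair shows this exact change. Going by the values given here, the only step that bears on it is a number 0.82 log units lower from compound 2 to compound 3 (beyond the scatter), which shows that amino at this place gives a lower number than bromo. Hydrogen at the same place is untested; a value between those of compound 2 and compound 3 is plausible, but a value no different from compound 3 beyond the scatter cannot be ruled out.

Compound 4 is therefore expected to give 6.5 in this assay, with a range from 5.95 to 7.05. The expected step is a number 0.32 log units higher from compound 3 to compound 4 (beyond the scatter).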

Compound 4, logarithm of the reciprocal of the active concentration, log(1/C): 6.25
Compound 4: middle estimate off by 0.25 log units, on the high side; low and high end bracket the measured number.
By their numbers in this assay, from the lowest: compounds 1, 3 and 4 (each within the scatter of the next); then compound 2.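

In this assay, hydrogen and amino on this aromatic carbon cannot be told apart: a number 0.07 log units higher from compound 3 to compound 4 (within the scatter) is the step between them. Among the compounds shown here, with a number 0.75 log units lower from compound 2 to compound 4 (beyond the scatter) alongside, bromo is the only one of the three groups at this place that goes with the higher number, and the gap to compound 2 is of like size whichever of the other two groups replaces it. Chloro and methyl cannot be told apart either, given a number 0.16 log units higher from compound 1 to compound 4 (within the scatter) for chloro in place of methyl on an aromatic carbon. Nothing at hand gives a reason for these numbers.

From the compounds shown here alone, whether the higher number belongs to bromo alone or extends to iodo, fluoro or a methoxy group on this carbon stays open. Going by these compounds, how a carboxylic acid or a longer chain would read there is equally open.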